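Nitrophenyl for Pyridyl on a Benzothiazole Triazole Acetamide

This account rests on a few compounds, and the source may have more. Where it says the series, first, only, none or still open, it means among the compounds named here.

Compound 1 `Cc1cc(NC(=O)Cn2cc(-c3ccc([N+](=O)[O-])cc3)nn2)no1`: 1220 nM
Compound 2 `O=C(Cn1cc(-c2ccncc2)nn1)Nc1nc2ccccc2s1`: 50 nM

In a functional assay on BMDM cells (Mus musculus, strain C57BL/6) for inhibition, with a stated time of 2 days (on this read-out higher numbers stand for weaker inhibition and lower numbers for stronger inhibition), compound 2 gives 50 nM, the lower of the two numbers recorded; compound 1 stands well above it, and the two structures differ in more than one place, so no single step can be read from that gap. Compound 3 `O=C(Cn1cc(-c2ccc([N+](=O)[O-])cc2)nn1)Nc1nc2ccccc2s1` carries the change (4-nitrophenyl in place of pyridin-4-yl on an aromatic carbon). The step is expected to cost some potency, a 3.2-fold higher number from compound 2 to compound 3 (0.51 log units; beyond the scatter), since compound 1 with the same entering group sits at 1220 nM. Compound 3 is therefore estimated at 160 nM, with a range from 40 nM to 650 nM.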

Compound 3, half-maximal inhibitory concentration: 3280 nM
Compound 3: middle estimate off by 21-fold (1.31 log units), on the low side; measured number above the stated range.
By their numbers in this assay, from the lowest: compound 2; then compound 1; then compound 3.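

On the aromatic carbon of the five-membered ring with 3 nitrogen, 4-nitrophenyl in place of pyridin-4-yl is a large loss in this assay (a 66-fold higher number from compound 2 to compound 3 (1.82 log units; beyond the scatter)). With 4-nitrophenyl held fixed, 1,3-benzothiazol-2-yl in place of 5-methyl-1,2-oxazol-3-yl on the amide-type nitrogen gives a modest step in the same direction (a 2.7-fold higher number from compound 1 to compound 3 (0.43 log units; beyond the scatter)), so 1,3-benzothiazol-2-yl alone does not bring the low number of compound 2. No measurement at hand explains either step.

Going by these compounds, whether plain phenyl, 4-aminophenyl or pyridin-3-yl on this carbon would stand nearer compound 2 or compound 3 remains open. So does the number that 5-methyl-1,2-oxazol-3-yl would give paired with pyridin-4-yl.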